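Swapping Bromo for Chloro on a Benzimidazole Nucleoside Core

The source may hold more compounds than are shown below. What is called first, only, known or untested is meant among the compounds shown, and "the series" means these compounds.

Two nucleoside analogues have been measured in an ADME assay on Rat2 cells (Rattus norvegicus) for cytotoxicity, read by XTT assay, with a stated time of 8 days; on this read-out higher numbers stand for lower toxicity in this test and lower numbers for higher toxicity in this test. Compound 1 `CC(=O)OC[C@H]1O[C@@H](n2c(Br)nc3c(Cl)c(Cl)c(Cl)cc32)[C@H](OC(C)=O)[C@@H]1OC(C)=O` carries three acetyl esters on its sugar and a bromo group together with three chloro groups on its fused core; in this assay compound 1 gives 14500 nM. Compound 2 `OC[C@H]1O[C@@H](n2c(Br)nc3cc(Cl)c(Cl)cc32)[C@H](O)[C@@H]1O` has free hydroxyl groups on the sugar and two chloro groups on the core; in this assay compound 2 gives 136000 nM. Of the two numbers, compound 1 has the lower one, so it is the more toxic of the pair on this read-out, and the gap lies beyond the usual scatter. Compound 3 `CC(=O)OC[C@H]1O[C@@H](n2c(Cl)nc3c(Cl)c(Cl)c(Cl)cc32)[C@H](OC(C)=O)[C@@H]1OC(C)=O` has not yet been measured. Among the measured compounds shown here, its only difference from compound 1 is chloro in place of bromo on an aromatic carbon, placed on an aromatic carbon of a five-membered aromatic ring with 2 nitrogen, between two ring nitrogen atoms. For the measured compounds named here, no measured pair shows the effect of this change, so the expected step from compound 1 to compound 3 is small, a 1.0-fold higher number from compound 1 to compound 3 (0.01 log units; within the scatter), not beyond the scatter in either direction. Compound 3 is therefore estimated at 15000 nM, with a range from 5000 nM to 45000 nM.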

Compound 3, half-maximal cytotoxic concentration: 19200 nM
Compound 3: the middle estimate sits 1.3-fold (0.11 log units) below what was measured, and the stated range covers the measured number.
By their numbers in this assay, from the lowest: compounds 1 and 3 (each within the scatter of the next); then compound 2.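

In this assay, chloro in place of bromo on an aromatic carbon gives a 1.3-fold higher number from compound 1 to compound 3 (0.12 log units; within the scatter), so at this place, between two ring nitrogen atoms, the two halogens cannot be told apart on this read-out. Among the compounds shown here, this is the first direct reading of this position, since compound 1 and compound 2 differ in more than one place and cannot isolate what the group there contributes. No measurement at hand explains why the two numbers lie so close, so the result stands as an observation only.

As far as these compounds go, both halogens have so far been read only on a core with three chloro groups and a sugar with three acetyl esters, so it remains open whether the swap would be just as quiet with free hydroxyl groups on the sugar and two chloro groups on the core, as in compound 2. The compounds shown also leave open what an amine, a methoxy group or a longer carbon chain at this same place would do to the number in this assay.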